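Para-substituent swap on the phenyl ring of the oxazole series

The compounds below may be only part of what the source reports. "The series", "measured", "known", "first", "only" and "open" are said of these compounds alone.

Two members of the series have numbers in a functional assay on LNCaP cells (Homo sapiens) for cytotoxicity, read by MTT assay, with a stated time of 48 h; a lower number here means a stronger inhibitor, a higher number a weaker inhibitor. Compound 1 `c1ccc(-c2nc(-c3c[nH]c4ccccc34)co2)cc1` gives 461000 nM, and compound 2 `Fc1ccc(-c2nc(-c3c[nH]c4ccccc34)co2)cc1` gives 59800 nM. Among the measured compounds shown here, the only step available, a 7.7-fold lower number from compound 1 to compound 2 (0.89 log units; beyond the scatter), leaves compound 2 with the lowest number of the two, with compound 1 the nearest at that distance.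

Compound 3 `Oc1ccc(-c2nc(-c3c[nH]c4ccccc34)co2)cc1` differs from compound 2 by hydroxy in place of fluoro on an aromatic carbon. For the measured compounds named here, no measured step covers a hydroxy at this place; the sole step, from hydrogen to fluoro, was modest and beyond the scatter, so the fluoro appears to carry part of the difference between compound 1 and compound 2. Removing it and putting in hydroxy, a group with no measured comparison here, is therefore expected to move the number back toward compound 1, by a 2.0-fold higher number from compound 2 to compound 3 (0.30 log units; within the scatter), with wide uncertainty. For compound 3 in this assay the estimate is 120000 nM, expected to lie between 30000 nM and 500000 nM.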

Compound 3, half-maximal inhibitory concentration: 449000 nM
Compound 3: the middle estimate sits 3.7-fold (0.57 log units) below what was measured; the measured number falls inside the stated range.
By their numbers in this assay, from the lowest: compound 2; then compounds 3 and 1 (each within the scatter of the next).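

In this assay, the change at this place on the aromatic ring does not simply follow from the presence of a substituent: hydroxy in place of fluoro gives a 7.5-fold higher number from compound 2 to compound 3 (0.88 log units; beyond the scatter). Hydroxy in place of hydrogen gives a 1.0-fold lower number from compound 1 to compound 3 (0.01 log units; within the scatter), so the hydroxy of compound 3 and the hydrogen of compound 1 cannot be told apart here, and among these three groups only the fluoro of compound 2 stands apart from the others. The data on hand give no reason for this difference.

On these data alone, whether the lower number is particular to fluoro or is shared by other halogens such as chloro or bromo stays open. So does the effect of a methoxy or an amine at this place, or of any of these groups elsewhere on the ring.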